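Two weak inhibitors and a methyl-for-methoxy swap

The compounds below may be only part of what the source reports. "The series", "measured", "known", "first", "only" and "open" are said of these compounds alone.

Measured compounds:
- compound 1, `Cc1cccc(COc2ccc(-c3nn(CCC#N)c(=O)o3)cc2)c1`: 20000 nM
- compound 2, `COc1cccc(COc2ccc(C3=NN(CCC#N)C(=O)CO3)cc2)c1`: 32000 nM

Among the measured compounds shown here, in an assay for inhibition of Amine oxidase [flavin-containing] A (Rattus norvegicus) (on this read-out lower numbers stand for stronger inhibition and higher numbers for weaker inhibition), compound 2 gives 32000 nM, the higher of the two numbers measured so far. Its nearest neighbour is compound 1, which in this assay gives 20000 nM; the gap between these two values lies within the usual scatter of repeated measurements, so nothing can be said about their order. The two compounds also differ in more than one place, so no single step can be read from them.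

Compound 3, `Cc1ccc(COc2ccc(C3=NN(CCC#N)C(=O)CO3)cc2)cc1`, has not yet been measured. It differs from compound 2 in one place: 4-methylphenyl in place of 3-methoxyphenyl on a saturated chain carbon bound to an oxygen on an aromatic ring. For the measured compounds named here, with no step between measured compounds available, the expectation rests on the size of the change alone, a small group exchanged on the outer ring. The step from compound 2 to compound 3 in this assay is expected to be a 1.3-fold lower number from compound 2 to compound 3 (0.11 log units; within the scatter), that is, none beyond the scatter. For compound 3 the estimate is 25000 nM, with a range from 8000 nM to 80000 nM.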

Compound 3, half-maximal inhibitory concentration: 250000 nM
For compound 3 the middle estimate is 10-fold (1.00 log units) below the measured one; measured number above the stated range.
By their numbers in this assay, from the lowest: compounds 1 and 2 (each within the scatter of the next); then compound 3.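

In this assay, the aryl group on a saturated chain carbon bound to an oxygen on an aromatic ring turns out not to be a silent position: 4-methylphenyl in place of 3-methoxyphenyl gives a 7.8-fold higher number from compound 2 to compound 3 (0.89 log units; beyond the scatter), which means weaker inhibition. Among the compounds shown here, this is the first single-place step, as compounds 1 and 2 differ in more than one place and could show nothing of the kind; it shows that an exchange on the outer ring, with the shared core and the nitrile-bearing chain unchanged, is enough to move the number beyond the scatter. Nothing available explains why this exchange weakens inhibition.

The step changes both the substituent and its numbered place on the ring, so the compounds shown cannot tell whether the loss follows from losing the methoxy group, from moving to the 4-position, or from both. As far as these compounds go, that question stays open until the shared core is seen with 3-methylphenyl or 4-methoxyphenyl on this carbon, and an unsubstituted phenyl would show what either substituent contributes.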